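Methoxy to chloro at the assay limit

A few compounds are considered here, and "the series" means these few. Any claim that something is new, unique, unknown or untested is made for them only; others in the source may bear on it.

Compound 1 `Cc1ccc(Cn2ccc3nc(-c4ccccc4)nc-3c2)cc1` gives > 100000 nM as a limit
Compound 2 `COc1cccc(Cn2ccc3nc(-c4ccccc4)nc-3c2)c1` gives > 100000 nM as a limit

In an ADME assay on MDBK cells (Bos taurus) for cytotoxicity (on this read-out higher numbers stand for lower toxicity in this test and lower numbers for higher toxicity in this test), compound 2 stands at > 100000 nM and this is a limit, not a number. For the measured compounds named here, the one further value, that of compound 1, is a limit too. Compound 3 `Clc1cccc(Cn2ccc3nc(-c4ccccc4)nc-3c2)c1` carries chloro in place of methoxy on an aromatic carbon and is still to be measured. Going by the values given here, the only measured step bearing on this change is a step that the two limits leave unreadable from compound 1 to compound 2 and it offers no size to carry over. The record so far is the limit of > 100000 nM in this assay, at which 2 of the 2 values shown sit, and nothing more. No step beyond the scatter is therefore expected in this assay and no direction can be given. The expected change is a number no higher from compound 2 to compound 3 (the limit leaves the size open) in this estimate. Compound 3 is expected at 100000 nM with an estimated range from 50000 nM to 200000 nM. A limit is expected again for compound 3.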

Compound 3, half-maximal cytotoxic concentration: > 100000 nM
Compound 3: a limit, no number; the forecaster's own chance of this, stated with the estimate: 75%; the middle value sits exactly at the limit.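

Compound 3 gives > 100000 nM in this assay, again a limit and not a number, and its steps from compound 1 and compound 2 cannot be read. The compounds shown leave open whether the change of group on the phenyl ring alters this read-out at all, with every value at the same limit: the limit of > 100000 nM in this assay, at which 3 of the 3 values shown sit.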